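The source may hold more compounds than are shown below. What is called first, only, known or untested is meant among the compounds shown, and "the series" means these compounds.

Compound 1, `Cn1c(-c2ccc(NC(=O)CCl)cc2)nc(-c2ccccc2)c1-c1ccccc1`, gives 14.4% in a functional assay on HT-29 cells (Homo sapiens) for cytotoxicity, read by MTT assay, with a stated time of 24 h, tested at 1.6 ug/mL; a higher number here means a stronger effect of the compound at the concentration tested, a lower number a weaker effect.
Compound 2, `Cn1ccnc1SCC(=O)Nc1ccc(-c2nc(-c3ccccc3)c(-c3ccccc3)n2C)cc1`, gives 23.8% in this assay.
Compound 3, `Cn1c(-c2ccc(NC(=O)CN3CCN(c4ccccc4)CC3)cc2)nc(-c2ccccc2)c1-c1ccccc1`, gives 26% in this assay.

Compound 3 holds the highest of the three numbers. The step of a number 11.6 percentage points higher from compound 1 to compound 3 (beyond the scatter) is beyond the scatter, while the step of a number 2.2 percentage points higher from compound 2 to compound 3 (within the scatter) is not; so compound 3 cannot be called the most active of the set.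

Compound 4, `COc1ccc(CN2CCN(CC(=O)Nc3ccc(-c4nc(-c5ccccc5)c(-c5ccccc5)n4C)cc3)CC2)cc1`, is compound 3 with one change: 4-methoxybenzyl in place of phenyl on an amine nitrogen in a ring.

Within the data shown here, none of the measured steps bears on this change. Among the measured compounds shown here, the steps of a number 9.4 percentage points higher from compound 1 to compound 2 (within the scatter), a number 11.6 percentage points higher from compound 1 to compound 3 (beyond the scatter) and a number 2.2 percentage points higher from compound 2 to compound 3 (within the scatter) all concern the group on the saturated chain carbon bound to the carbonyl carbon; no measured pair differs at the amine nitrogen in the ring. With nothing to build on, compound 4 is expected to stay close to compound 3, with a step of a number 1 percentage points higher from compound 3 to compound 4 (within the scatter), that is, none beyond the scatter.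

Compound 4 is therefore estimated at 27% in this assay, between 14% and 40%.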

Compound 4, a percentage reported as activity, at one concentration (the size of the read-out at that concentration, not a potency): 10.1%
Estimate against measurement, compound 4: 16.9 percentage points above; the measured number lies below the stated range.
By their numbers in this assay, from the lowest: compounds 4, 1, 2 and 3 (each within the scatter of the next, the first and the last beyond it).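

Unlike the earlier steps, which all concerned the group on the saturated chain carbon bound to the carbonyl carbon, this result shows that the read-out also responds to a change on the amine nitrogen in the ring: in this assay there is a number 15.9 percentage points lower from compound 3 to compound 4 (beyond the scatter) with 4-methoxybenzyl in place of phenyl. The change keeps one six-membered aromatic ring of carbon only while going from 6 to 9 heavy atoms and from 0 to 1 hydrogen-bond acceptor, so an aromatic ring on this nitrogen does not by itself preserve the number. Nothing available here accounts for the size or direction of this step.

From the compounds shown here alone, whether the step follows from the methoxy group or from the added carbon link remains open, and a plain benzyl group on that nitrogen would separate the two. Going by these compounds, how a 4-methoxyphenyl group or a methyl group would read at this position also remains open.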